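Tert-butyl to Propyl on the Shared Core

This account rests on a few compounds, and the source may have more. Where it says the series, first, only, none or still open, it means among the compounds named here.

Three measured compounds share one core and differ only in the group on one aromatic carbon. In an assay on membranes from HEK293 cells for displacement of a labelled ligand from Type-2 angiotensin II receptor (Homo sapiens), read by radioligand binding (on this read-out higher numbers stand for weaker inhibition and lower numbers for stronger inhibition), compound 1 `CCCCOC(=O)NS(=O)(=O)c1ccc(CCC)cc1-c1ccc(Cn2c(C3CCCCC3)nc3ccccc32)cc1` gives 130 nM. Compound 2 `CCCCOC(=O)NS(=O)(=O)c1ccc(CCC)cc1-c1ccc(Cn2c(-c3ccccc3)nc3ccccc32)cc1` gives 590 nM. Compound 3 `CCCCOC(=O)NS(=O)(=O)c1ccc(CCC)cc1-c1ccc(Cn2c(C(C)(C)C)nc3ccccc32)cc1` gives 5.3 nM, the lowest number of the three, beyond the scatter from both others. The steps of a 25-fold lower number from compound 1 to compound 3 (1.39 log units; beyond the scatter) and a 110-fold lower number from compound 2 to compound 3 (2.05 log units; beyond the scatter) show that tert-butyl at this position gave the strongest binding measured so far. Compound 4 `CCCCOC(=O)NS(=O)(=O)c1ccc(CCC)cc1-c1ccc(Cn2c(CCC)nc3ccccc32)cc1` carries the change (propyl in place of tert-butyl on an aromatic carbon). Among the measured compounds shown here, no measured step covers propyl directly, so the measured steps only show that leaving tert-butyl cost binding in both cases; a modest rise in number is therefore expected. Compound 4 is estimated at 20 nM in this assay, with a range from 5 nM to 80 nM. This expected step is a 3.8-fold higher number from compound 3 to compound 4 (0.58 log units; beyond the scatter).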

Compound 4, inhibition constant: 14 nM
Beside the measured number, compound 4's estimate is 1.4-fold (0.15 log units) above it; the range from low to high includes it.
By their numbers in this assay, from the lowest: compound 3; then compound 4; then compound 1; then compound 2.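

Propyl does not fully match tert-butyl at this position, with a 2.6-fold higher number from compound 3 to compound 4 (0.42 log units; beyond the scatter), but it binds far better than either ring-bearing group, with a 42-fold lower number from compound 2 to compound 4 (1.62 log units; beyond the scatter) and a 9.3-fold lower number from compound 1 to compound 4 (0.97 log units; beyond the scatter). Across all four compounds, the two groups without a ring therefore give lower numbers than cyclohexyl and phenyl, so a ring at this carbon is not needed for strong binding. No evidence at hand explains this order.

On these data alone, whether ethyl, butyl or isopropyl would come closer to tert-butyl remains open. So does the effect of an amine or a methoxy group on this carbon.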